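One Flipped Stereocentre: What to Expect of Compound 4

This account rests on a few compounds, and the source may have more. Where it says the series, first, only, none or still open, it means among the compounds named here.

In a functional assay on A549 cells (Homo sapiens) for antiproliferative activity, read by XTT assay, with a stated time of 72 h (on this read-out lower numbers stand for stronger inhibition and higher numbers for weaker inhibition), compound 2 `C=C(C)CC[C@]1(C)C2=CCC[C@](C)(C[C@@H](O)C3=CC(=O)OC3O)[C@H]2CC[C@H]1C` gives 4400 nM and lies within the scatter of compound 1 `C=C(C)CCC[C@]1(C)C2=CCC[C@](C)(C[C@@H](O)C3=CC(=O)OC3O)[C@H]2CC[C@H]1C` with 3800 nM but lower than compound 3 `C=C(C)CC[C@]1(C)C2=CCC[C@](C)(C[C@@H](OC(C)=O)C3=CC(=O)OC3O)[C@H]2CC[C@H]1C` with 11100 nM on this scale. Compound 4 `C=C(C)CC[C@]1(C)C2=CCC[C@](C)(C[C@H](O)C3=CC(=O)OC3O)[C@H]2CC[C@H]1C` has the same atoms and bonds as compound 2 with the two compounds have the same atoms and bonds; at least one stereo element is drawn with a configuration in one of them and without one in the other: 1 of 6 stereo elements differ; a stereocentre at a saturated chain carbon is drawn R in compound 2 and S in compound 4 in the drawing, as a stereocentre at a saturated chain carbon is drawn R in compound 2 and S in compound 4. Among the measured compounds shown here, no measured step inverts a stereocentre, so the guidance is indirect. Changing the chain group gave a 1.2-fold higher number from compound 1 to compound 2 (0.06 log units; within the scatter) and placing acetyl on an oxygen on a saturated carbon gave a 2.5-fold higher number from compound 2 to compound 3 (0.40 log units; beyond the scatter) as the larger move. Neither step gives a direction here, so no change beyond the scatter is expected in this assay and the estimated move is a 1.1-fold higher number from compound 2 to compound 4 (0.06 log units; within the scatter) with either direction possible. Compound 4 is expected near 5000 nM within an estimated range of 2000 nM to 12000 nM in this assay.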

Compound 4, half-maximal inhibitory concentration: 4500 nM
Estimate against measurement, compound 4: 1.1-fold (0.05 log units) above; the measured number falls inside the stated range.
By their numbers in this assay, from the lowest: compounds 1, 2 and 4 (each within the scatter of the next); then compound 3.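

Among the compounds shown here, at this stereocentre at a saturated chain carbon, the drawn configuration alone gives a 1.0-fold higher number from compound 2 to compound 4 (0.01 log units; within the scatter) in this assay and so leaves the number unchanged within the scatter, which the earlier steps, both of which changed groups, could not show. Reading this as a clean swap of one configuration for the other needs caution: the fact that one of compounds 2 and 4 is drawn with a defined configuration and the other without, at the place where they differ.

The compounds shown leave open whether the drawn configuration would matter with the acetyl of compound 3 on that oxygen. They also leave open whether it would matter with an amine in place of the hydroxyl.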